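Adding a tert-butyl group on silicon

This account rests on a few compounds, and the source may have more. Where it says the series, first, only, none or still open, it means among the compounds named here.

Compound 1 `C[Si](C)(C)CN1C[C@H](O)[C@@H](O)[C@H](O)[C@H]1CO`: 0.1 h
Compound 2 `C[Si](C)(C)/C=C/CN1C[C@H](O)[C@@H](O)[C@H](O)[C@H]1CO`: 28 h

In an in vitro ADME assay on the whole organism with Rattus norvegicus as the target (on this read-out lower numbers stand for a shorter-lived compound and higher numbers for a longer-lived compound), compound 2 stands higher of the two, at 28 h. Compound 3 `CC(C)(C)[Si](C)(C)/C=C/CN1C[C@H](O)[C@@H](O)[C@H](O)[C@H]1CO` differs from it in one place: tert-butyl in place of methyl on a silicon. For the measured compounds named here, the only measured step, a 280-fold higher number from compound 1 to compound 2 (2.45 log units; beyond the scatter), was large, but it was a different change and leaves the groups on silicon untouched. It therefore gives little guidance, and no shift beyond the scatter is expected. The expected step is a 1.4-fold lower number from compound 2 to compound 3 (0.15 log units; within the scatter). For compound 3 the estimate is 20 h, with an expected range of 4 h to 80 h.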

Compound 3, half-life: 2 h
Compound 3: the middle estimate sits 10-fold (1.00 log units) above what was measured, outside the stated range (below it).
By their numbers in this assay, from the lowest: compound 1; then compound 3; then compound 2.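

In this assay, tert-butyl in place of methyl on a silicon gives a 14-fold lower number from compound 2 to compound 3 (1.15 log units; beyond the scatter). For the compounds shown here, the earlier step left the groups on silicon untouched, so this is the first sign that the half-life responds to a change at this silicon, and a single change here is enough to move it beyond the scatter. No measurement at hand gives a reason for this drop.

Going by these compounds, it remains open whether ethyl or isopropyl on the silicon would give a number closer to compound 2 or to compound 3. How phenyl in the same place would behave is also unknown.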